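Shortening the Amine Tail in a Benzimidazole Series

This account rests on a few compounds, and the source may have more. Where it says the series, first, only, none or still open, it means among the compounds named here.

Measured compounds:
Compound 1 `CCN(CC)CCn1c(N)c(-c2nc3ccccc3[nH]2)c2nc(C#N)c(C#N)nc21` gives 1880 nM in a functional assay on HL-60 cells (Homo sapiens) for antiproliferative activity, read by MTT assay, with a stated time of 48 h; a lower number here means a stronger inhibitor, a higher number a weaker inhibitor.
Compound 2 `CN(C)CCCn1c(N)c(-c2nc3ccccc3[nH]2)c2nc(C#N)c(C#N)nc21` gives 870 nM in this assay.
Compound 3 `CCN(CC)CCCn1c(N)c(-c2nc3ccccc3n2C)c2nc(C#N)c(C#N)nc21` gives 2810 nM in this assay.

Compound 1 and compound 2 differ in one place: (dimethylamino)methyl in place of diethylamino on a saturated chain carbon, two bonds along the chain from an aromatic nitrogen. That change gave a 2.2-fold lower number from compound 1 to compound 2 (0.33 log units; beyond the scatter). Compound 3 carries a core that differs from the core of compound 1, and that difference is not broken down here. Compound 4 `CN(C)CCCCn1c(N)c(-c2nc3ccccc3n2C)c2nc(C#N)c(C#N)nc21` has not been measured yet; it differs from compound 3 by (dimethylamino)methyl in place of diethylamino on a saturated chain carbon, three bonds along the chain from an aromatic nitrogen. This is the same kind of change as that from compound 1 to compound 2, but the place is not identical: in the earlier pair the change sits two bonds along the chain from an aromatic nitrogen, in the new pair three bonds along. Because the earlier change gave a 2.2-fold lower number from compound 1 to compound 2 (0.33 log units; beyond the scatter), a step of similar size is expected from compound 3 to compound 4 in this assay, namely a 2.2-fold lower number from compound 3 to compound 4 (0.33 log units; beyond the scatter). The expected value for compound 4 is 1300 nM, most likely between 500 nM and 3200 nM.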

Compound 4, half-maximal inhibitory concentration: 740 nM
Compound 4: middle estimate off by 1.8-fold (0.24 log units), on the high side; measured number inside the range.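

Replacing diethylamino with (dimethylamino)methyl on the second core gave a 3.8-fold lower number from compound 3 to compound 4 (0.58 log units; beyond the scatter) in this assay, so the change that helped on the core of compound 1 also helped on the core of compound 3. This does not show that the change would carry to any other core, since two pairs are a small sample. It also does not separate the two things that alter together in each pair, the amine end and the chain length. The two steps point the same way, and their sizes cannot be told apart: the same change on two cores in this assay, a 2.2-fold lower number (0.33 log units; beyond the scatter) from compound 1 to compound 2 and a 3.8-fold lower number (0.58 log units; beyond the scatter) from compound 3 to compound 4, 1.8-fold (0.24 log units) apart, within the scatter of two such steps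

The compounds shown leave open which of those two alterations matters, since no pair here changes the amine end while keeping the chain length, or the reverse. They also leave open whether a ring amine such as morpholine or pyrrolidine, or a chain longer than 4-(dimethylamino)butyl, would follow the same trend on either core.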